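Replacing a Dipropylamino Group with an Isopropoxypiperidine

The source may hold more compounds than are shown below. What is called first, only, known or untested is meant among the compounds shown, and "the series" means these compounds.

Compound 1 `CC(C(=O)NCc1ccc(C(F)(F)F)nc1NC1CCCCC1)c1ccc(NS(C)(=O)=O)c(F)c1`: 20.4 nM
Compound 2 `CCCN(CCC)c1nc(C(F)(F)F)ccc1CNC(=O)C(C)c1ccc(NS(C)(=O)=O)c(F)c1`: 0.2 nM
Compound 3 `CC1CCCN1c1nc(C(F)(F)F)ccc1CNC(=O)[C@@H](C)c1ccc(NS(C)(=O)=O)c(F)c1`: 0.3 nM

In a functional assay on CHO-K1 cells for antagonist activity at transient receptor potential cation channel subfamily V member 1 (Homo sapiens), read by FLIPR (a higher number here means a weaker inhibitor, a lower number a stronger inhibitor), compound 2 gives the lowest of the three numbers; compound 3 lies within the scatter of it, while compound 1 sits far above. Going by the values given here, the only single-point step measured, a 100-fold lower number from compound 1 to compound 2 (2.01 log units; beyond the scatter), shows that this position tolerates large swings. Compound 4 `CC(C)OC1CCN(c2nc(C(F)(F)F)ccc2CNC(=O)C(C)c2ccc(NS(C)(=O)=O)c(F)c2)CC1` differs from compound 2 by 4-isopropoxypiperidin-1-yl in place of dipropylamino on an aromatic carbon. Among the compounds with values here, no measured step covers this exact change, but compound 3 shows that a ring-closed amine at this place keeps the number low. A modest rise is therefore expected, a 5.0-fold higher number from compound 2 to compound 4 (0.70 log units; beyond the scatter), and for compound 4 the estimate in this assay is 1 nM, with a range from 0.2 nM to 5 nM.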

Compound 4, inhibition constant: 3 nM
Estimate against measurement, compound 4: 3.0-fold (0.48 log units) below, and the stated range covers the measured number.
By their numbers in this assay, from the lowest: compounds 2 and 3 (each within the scatter of the next); then compound 4; then compound 1.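

In this assay, 4-isopropoxypiperidin-1-yl in place of dipropylamino gives a clear loss (a 15-fold higher number from compound 2 to compound 4 (1.18 log units; beyond the scatter)), so a ring-closed amine at this place does not always hold the number at the level of compound 2. The same group still outperforms cyclohexylamino (a 6.8-fold lower number from compound 1 to compound 4 (0.83 log units; beyond the scatter)), so the position keeps a low number with this larger ring group. Nothing available here explains either step.

Going by these compounds, whether the rise belongs to the isopropoxy group or to the piperidine ring itself remains open. An unsubstituted piperidine or a 4-methoxypiperidine at this place would help separate the two.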